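Swapping a Trifluoromethyl for a Methoxy on the Ester

The compounds below may be only part of what the source reports. "The series", "measured", "known", "first", "only" and "open" are said of these compounds alone.

The compounds here share one core, a bicyclic framework carrying an isopropyl group and two methyls, joined through an ester to a second benzene ring that carries a single substituent. Compound 1 `Cc1cc2c(C(C)C)ccc(C)c2cc1OC(=O)c1cccc(C(F)(F)F)c1` bears a trifluoromethyl on that ring. In a functional assay on HCT-15 cells (Homo sapiens) for antiproliferative activity, read by sulforhodamine B assay, with a stated time of 48 h, tested at 50 uM (a higher number here means more inhibition at the concentration tested (going by the name of the read-out), a lower number less inhibition), compound 1 is recorded as "not active" (no number reported), so no number places it on the scale; it can only be said to have shown no noteworthy inhibition.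

Two related compounds with a partly saturated core give numbers. Compound 2 `CC1=CC[C@H](C(C)C)c2cc(C)c(OC(=O)c3cccc(C)c3)cc21` gives 5.3% in this assay, and compound 3 `CC1=CC[C@H](C(C)C)c2cc(C)c(OC(=O)c3cccc([N+](=O)[O-])c3)cc21` gives 45.9%. For the measured compounds named here, the one step measured between them, a number 40.6 percentage points higher from compound 2 to compound 3 (beyond the scatter), shows that a change of substituent on this ring can shift the read-out a great deal.

Compound 4 `COc1cccc(C(=O)Oc2cc3c(C)ccc(C(C)C)c3cc2C)c1` differs from compound 1 by one exchange (methoxy in place of trifluoromethyl on an aromatic carbon). Going by the values given here, no measured step concerns a methoxy or a trifluoromethyl, so the only footing is that compound 1 was reported as not active and that compound 2, with a small uncharged group, sat near the bottom of the scale. A low read-out is therefore expected, with a real chance that again no number is reported. For compound 4 the inhibition is estimated at 8%, in a range from 0% to 25%.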

Compound 4, a percentage reported as inhibition, at one concentration (the size of the read-out at that concentration, not a potency): 35.2%
The estimate for compound 4 lay 27.2 percentage points below the measured number; measured number outside the range, above it.
By their numbers in this assay, from the lowest: compound 2; then compound 4; then compound 3.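

For the compounds shown here, compound 1 is recorded as "not active" (no number reported) while compound 4 gives 35.2% as a number, so no step between the two can be read. Nothing measured here explains this result. The compounds shown leave open how methoxy and trifluoromethyl compare on one shared core when both carry a number.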